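The compounds below may be only part of what the source reports. "The series", "measured", "known", "first", "only" and "open" are said of these compounds alone.

Measured compounds:
- compound 1, `O=C(c1cccnc1)n1c(-c2cn(-c3ccccc3)nc2-c2ccc(F)cc2)nc2ccccc21`: 216000 nM
- compound 2, `Cc1ccc(C(=O)n2c(-c3cn(-c4ccccc4)nc3-c3ccc(C(F)(F)F)cc3)nc3ccccc32)cn1`: 153000 nM
- compound 3, `Cc1ccc(-c2nn(-c3ccccc3)cc2-c2nc3ccccc3n2C(=O)c2cccnc2)cc1`: 189000 nM

All three were read in an ADME assay on HEK-293T cells (Homo sapiens) for cytotoxicity, read by MTT assay, with a stated time of 24 h; on this read-out higher numbers stand for lower toxicity in this test and lower numbers for higher toxicity in this test. Among the three, compound 1 carries the largest number, but the one step through a single change, a 1.1-fold lower number from compound 1 to compound 3 (0.06 log units; within the scatter), is within the scatter, and the value of compound 2 also lies within the scatter of compound 1, so the three compounds are not separated on this read-out.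

Compound 4, `O=C(c1ccccc1)n1c(-c2cn(-c3ccccc3)nc2-c2ccc(F)cc2)nc2ccccc21`, has not been measured. It differs from compound 1 in one place: phenyl in place of pyridin-3-yl on a carbonyl carbon.

Among the measured compounds shown here, no measured step touches this place. For the measured compounds named here, the only step in hand, from compound 1 to compound 3, changes a substituent on an aromatic carbon and is within the scatter; compound 2 differs from compound 1 in two places at once, and its value simply sits within the scatter of compound 1. Nothing here speaks for a shift in either direction when pyridin-3-yl is exchanged for phenyl on the carbonyl carbon, and the series so far has shown no change beyond the scatter at all.

Compound 4 is therefore expected to give a number close to that of compound 1, with the step of a 1.1-fold lower number from compound 1 to compound 4 (0.03 log units; within the scatter) expected to stay within the scatter. The estimate for compound 4 is 200000 nM, with a range from 100000 nM to 400000 nM.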

Compound 4, half-maximal cytotoxic concentration: 180000 nM
Compound 4: the middle estimate sits 1.1-fold (0.05 log units) above what was measured; low and high end bracket the measured number.
By their numbers in this assay, from the lowest: compounds 2, 4, 3 and 1 (each within the scatter of the next).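

In this assay, among the compounds shown here, exchanging the ring on the carbonyl carbon gives the first reading at this place: a 1.2-fold lower number from compound 1 to compound 4 (0.08 log units; within the scatter). The hydrogen-bond acceptor counted in pyridin-3-yl is absent from phenyl, and on this read-out the two compounds are not separated, so that ring nitrogen is not required for a number in this range in this pair. No measurement on hand bears on the reason for this result.

For the compounds shown here, the reading covers only two six-membered aromatic rings on the carbonyl carbon, and it leaves open whether a saturated ring such as piperidine, a chain bearing a primary amine or a phenyl ring carrying a carboxylic acid would separate from compound 1 on this read-out. As no step in hand lies beyond the scatter, the compounds shown also leave open which change to the core of compound 1, if any, would shift the number in either direction.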